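A few compounds are considered here, and "the series" means these few. Any claim that something is new, unique, unknown or untested is made for them only; others in the source may bear on it.

Measured compounds:
compound 1, `Cc1nc(SCC(=O)Nc2nc(-c3ccc(Cl)cc3)cs2)n(Nc2ccccc2)c1C`, which in a functional assay on HCT-15 cells (Homo sapiens) for antiproliferative activity, read by sulforhodamine B assay, with a stated time of 48 h (on this read-out lower numbers stand for stronger inhibition of growth and higher numbers for weaker inhibition of growth), gives 23300 nM;
compound 2, `Cc1ccc(Nn2c(SCC(=O)Nc3nc(-c4ccccc4)cs3)nc(C)c2C)cc1`, for which this assay reports only a limit, > 100000 nM.

Among the compounds with values here, compound 1 thus holds the only actual number in this assay; the second value is a limit (the limit of > 100000 nM in this assay, at which 1 of the 2 values shown sits), so compound 1 cannot be placed above or below compound 2 with any confidence, only noted as the one whose growth inhibition was quantified.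

The unmeasured compound 3, `COc1ccc(Nn2c(SCC(=O)Nc3nc(-c4ccc(Cl)cc4)cs3)nc(C)c2C)cc1`, differs from compound 1 in one place: methoxy in place of hydrogen on an aromatic carbon. Within the data shown here, no step between measured compounds in this assay isolates this change, so its size rests on expectation alone. The step from compound 1 to compound 3 is estimated at a 1.7-fold higher number from compound 1 to compound 3 (0.23 log units; within the scatter), a modest shift toward weaker growth inhibition, not clearly beyond the scatter. Compound 3 is therefore expected to give about 40000 nM in this assay, within a range from 15000 nM to 100000 nM.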

Compound 3, concentration for total growth inhibition: > 100000 nM
Compound 3: a limit, no number; the forecaster's own chance of this, stated with the estimate: 30%; middle value at least 2.5-fold (0.39 log units) away from the limit.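

In this assay, within the data shown here, the change from anilino to (4-methoxyphenyl)amino gives an at least 4.2-fold higher number from compound 1 to compound 3 (0.63 log units; beyond the scatter), the first step that can be read at this position, and it lies beyond the scatter. Compound 3 stands at a limit and not at a number, so this step fixes only the least possible size of the change, and the quantified growth inhibition of compound 1 does not survive this single methoxy group. The values now gather at one end of the read-out: the limit of > 100000 nM in this assay, at which 2 of the 3 values shown sit.

Still open, as far as these compounds go, is whether another group on the same aromatic carbon, such as a fluorine, a hydroxyl or an amine, would keep a number in this assay. The compounds shown also leave open how far compound 3 lies past its limit.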